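The compounds below may be only part of what the source reports. "The series", "measured", "known", "first", "only" and "open" are said of these compounds alone.

Measured so far in a functional assay on COLO 205 cells (Homo sapiens) for inhibition, read by sulforhodamine B assay, with a stated time of 48 h, tested at 50 uM; on this read-out lower numbers stand for less inhibition of growth and higher numbers for more inhibition of growth at the one concentration tested:

Compound 1, `O=C1C(=O)N(CCCCCn2cc(COc3cc(=O)oc4ccccc34)nn2)c2ccc(Br)cc21`: 39%
Compound 2, `O=C1C(=O)N(CCCn2cc(COc3cc(=O)oc4ccccc34)nn2)c2ccc(Br)cc21`: 61%
Compound 3, `O=C1C(=O)N(CCCCn2cc(COc3cc(=O)oc4ccccc34)nn2)c2ccc([N+](=O)[O-])cc21`: 45%

Compound 3 gives the second highest of the three numbers in this assay. Its nearest neighbour is compound 1, whose number is a few points lower, a gap that falls within the scatter of repeated measurements. Its furthest neighbour is compound 2, whose number is higher by a gap that does lie beyond the scatter. Compound 1 and compound 3 differ in more than one place, in both the chain and the group on the fused ring, so nothing can be said about either change on its own from these two values.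

Within the data shown here, the next compound, compound 4, `O=C1C(=O)N(CCCCn2cc(COc3cc(=O)oc4ccccc34)nn2)c2ccc(I)cc21`, keeps the chain of compound 3 and changes only one group: iodo in place of nitro on an aromatic carbon. Among the measured compounds shown here, no pair already measured shows a change of this kind alone, so there is no measured step to lean on. The expectation is that the step of a number 2 percentage points higher from compound 3 to compound 4 (within the scatter) stays within the scatter, with no clear direction. In this assay compound 4 is therefore expected to give about 47%, with a likely range from 30% to 65%.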

Compound 4, percent growth inhibition at one concentration: 50%
Beside the measured number, compound 4's estimate is 3 percentage points below it; measured number inside the range.
By their numbers in this assay, from the lowest: compounds 1, 3 and 4 (each within the scatter of the next, the first and the last beyond it); then compound 2.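

In this assay, among these compounds, compound 3 and compound 4 form the first pair that differs in one place only, and the step is a number 5 percentage points higher from compound 3 to compound 4 (within the scatter). On this aromatic carbon, then, a nitro group of 3 heavy atoms with 2 hydrogen-bond acceptors can give way to an iodo group of 1 heavy atom with no hydrogen-bond acceptors, and the growth inhibition read at the one tested concentration shows no clear difference. This is a single exchange on a single chain, so it supports no general rule for the position, and no measurement at hand explains the result.

Going by these compounds, it remains open whether the same carbon would tolerate quite different groups, such as an amine or a carboxylic acid, with the chain of compound 3 held constant. On these data alone, it also remains open whether nitro and iodo would still give such similar numbers on a longer chain or at other concentrations, since a reading at one concentration cannot show how the two compounds compare across a range.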